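The source may report more compounds than this note shows. Statements on the series, on what has been measured and on what is new or still open speak of the compounds shown alone.

The measured compounds:
compound 1, `Nc1ccccc1NC(=O)c1ccc(CSC(=S)N2CCN(Cc3ccccn3)CC2)cc1`, 14.2%
compound 2, `CN(Cc1ccncc1)C(=S)SCc1ccc(C(=O)Nc2ccccc2N)cc1`, 29.5%

Compound 1, `Nc1ccccc1NC(=O)c1ccc(CSC(=S)N2CCN(Cc3ccccn3)CC2)cc1`, is the starting point of this account. For the measured compounds named here, in a functional assay on HeLa cells (Homo sapiens) for antiproliferative activity, read by CCK-8 assay, with a stated time of 72 h, tested at 2 uM (a lower number here means a weaker effect, a higher number a stronger effect of the compound at the concentration tested), compound 1 gives 14.2%, the lower of the two numbers measured so far. Compound 2, `CN(Cc1ccncc1)C(=S)SCc1ccc(C(=O)Nc2ccccc2N)cc1`, gives 29.5% in this assay, and the gap between the two values lies beyond the usual scatter, so compound 2 shows the stronger effect of the pair. Going by the values given here, no step between compounds that differ in a single place has been measured, so nothing directly tells how a change at the amine nitrogen in the ring shifts the read-out.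

Compound 3, `Nc1ccccc1NC(=O)c1ccc(CSC(=S)N2CCN(c3ccncc3)CC2)cc1`, differs from compound 1 in one place: pyridin-4-yl in place of (pyridin-2-yl)methyl on an amine nitrogen in a ring. Among the compounds with values here, with no measured step of this kind to lean on, the expected change is small, in neither direction beyond the scatter. The author expects, from the step of a number 3.8 percentage points higher from compound 1 to compound 3 (within the scatter), that compound 3 will give 18% in this assay, with a range from 5% to 35%, because compound 1 gave 14.2% and nothing measured argues for a large move away from it.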

Compound 3, a percentage reported as inhibition, at one concentration (the size of the read-out at that concentration, not a potency): 77%
For compound 3 the middle estimate is 59 percentage points below the measured one; the whole stated range lies below it.
By their numbers in this assay, from the lowest: compound 1; then compound 2; then compound 3.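

In this assay, putting pyridin-4-yl in place of (pyridin-2-yl)methyl on the amine nitrogen in the ring gives a number 62.8 percentage points higher from compound 1 to compound 3 (beyond the scatter), the first single-place change measured here, and it shows that the read-out depends strongly on what this nitrogen carries. The two groups are closely matched in what can be counted: 7 heavy atoms against 6, each with one six-membered aromatic ring with 1 hetero atom, 0 hydrogen-bond donors and 1 hydrogen-bond acceptor. No measurement shown here accounts for the size of this step.

As far as these compounds go, the step alters two things at once, the methyl link to the ring and the point of attachment on the pyridine, so it remains open which of them matters, and a compound carrying pyridin-2-yl directly on this nitrogen, or (pyridin-3-yl)methyl, would separate the two. From the compounds shown here alone, whether the pyridine ring nitrogen is needed at all also stays open, a plain phenyl at this position would address that, and since each value is taken at a single concentration, none of them is a potency.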